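The source may hold more compounds than are shown below. What is called first, only, known or untested is meant among the compounds shown, and "the series" means these compounds.

Measured so far:
compound 1, `O=C1NC(=O)/C(=C/c2ccccc2OCN2C(=O)c3ccccc3C2=O)S1`, in an assay on isolated protein for inhibition of Alpha glucosidase (Homo sapiens), read by spectrophotometry, with stated times of 15 min and 30 min (on this read-out lower numbers stand for stronger inhibition and higher numbers for weaker inhibition), compound 1 gives a value that is only a limit of the assay, > 100000 nM.
Compound 2, `COc1cccc(/C=C2\SC(=O)NC2=O)c1OCN1C(=O)c2ccccc2C1=O`, in this assay compound 2 gives a value that is also only a limit, > 100000 nM.
Compound 3, `COc1cc(/C=C2\SC(=S)NC2=O)ccc1OCN1C(=O)c2ccccc2C1=O`, in this assay compound 3 gives 16100 nM.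

Among the measured compounds shown here, the one change made twice here is methoxy in place of hydrogen on an aromatic carbon. Between compound 1 and compound 2 it gives a step that the two limits leave unreadable from compound 1 to compound 2, a step whose size cannot be read because of the limit of > 100000 nM in this assay, at which 2 of the 3 values shown sit. The difference between the core of compound 1 and the core of compound 3 is not broken down here.

Compound 4, `COc1cc(/C=C2\SC(=S)NC2=O)cc(OC)c1OCN1C(=O)c2ccccc2C1=O`, is not yet measured. It differs from compound 3 by methoxy in place of hydrogen on an aromatic carbon. For the measured compounds named here, this is the same kind of change as the one from compound 1 to compound 2, not the same: around the place in compound 4 the ring also carries a methoxy group meta to the new one.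

Since the earlier step is unreadable, the expectation rests mainly on compound 3 and its 16100 nM, and the step from compound 3 to compound 4 is expected to be about a 1.2-fold higher number from compound 3 to compound 4 (0.09 log units; within the scatter). Compound 4 is thus estimated at 20000 nM, between 7000 nM and 70000 nM.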

Compound 4, half-maximal inhibitory concentration: 39800 nM
Beside the measured number, compound 4's estimate is 2.0-fold (0.30 log units) below it; measured number inside the range.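

In this assay, putting methoxy in place of hydrogen on an aromatic carbon gives a 2.5-fold higher number from compound 3 to compound 4 (0.39 log units; beyond the scatter), so on this core the change goes with modestly weaker inhibition. Among the compounds shown here, the same change on the core of compound 1 offers no size to compare with this one, because its step to compound 2 cannot be read: the limit of > 100000 nM in this assay, at which 2 of the 4 values shown sit. The single readable step therefore describes one place, on a ring that also carries a methoxy group, and does not show that the change would weaken inhibition by a similar amount, or at all, on another core.

The compounds shown leave open whether a different group at this same place, such as a hydroxyl group, a fluorine atom or an amine, would give a step of another size or direction on the core of compound 3. They also leave open whether a longer chain, such as ethoxy, would raise the number further or lower it.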